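Swapping a pyridine for a pyridylmethyl group on compound 2

This account rests on a few compounds, and the source may have more. Where it says the series, first, only, none or still open, it means among the compounds named here.

Compound 1 `Cc1ccccc1Nc1nc(NCc2ccccc2)ncc1Cl`: > 100000 nM (a limit of the assay)
Compound 2 `Cc1ccccc1Nc1nc(Nc2cc(Cl)ccn2)ncc1Cl`: 41500 nM

Both compounds were tested in an ADME assay on L02 cells (Homo sapiens) for inhibition, read by CCK-8 assay, with a stated time of 48 h; on this read-out lower numbers stand for stronger inhibition of growth and higher numbers for weaker inhibition of growth. Among the measured compounds shown here, compound 2 stands at 41500 nM, the only true number so far. Compound 1 gives only a limit of the assay, > 100000 nM, and the limit of > 100000 nM in this assay, at which 1 of the 2 values shown sits, marks where it sits.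

The next compound is compound 3 `Cc1ccccc1Nc1nc(NCc2ccncc2)ncc1Cl`. It differs from compound 2 by (pyridin-4-yl)methyl in place of 4-chloropyridin-2-yl on a nitrogen on an aromatic ring.

For the measured compounds named here, one measured step bears on this change: an at least 2.4-fold lower number from compound 1 to compound 2 (0.38 log units; beyond the scatter), which lies beyond the scatter. Compound 1 carries benzyl, and compound 3 likewise carries a ring joined through a methyl group, although its ring holds a nitrogen. The change therefore runs roughly opposite to that step, so a higher number, meaning weaker inhibition of growth, is expected in this assay. The expected step is a 2.2-fold higher number from compound 2 to compound 3 (0.34 log units; beyond the scatter). Compound 3 may well report only a limit. For compound 3 the estimated value is 90000 nM, with an expected range from 40000 nM to 200000 nM.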

Compound 3, concentration for 50% growth inhibition: > 100000 nM
Compound 3 ended at the assay's limit; the forecaster's own chance of this, stated with the estimate: 50%; at least 1.1-fold (0.04 log units) between middle value and limit.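

In this assay, the change on this nitrogen gives an at least 2.4-fold higher number from compound 2 to compound 3 (0.38 log units; beyond the scatter), so compound 3, with (pyridin-4-yl)methyl, inhibits growth more weakly than compound 2, with 4-chloropyridin-2-yl. Compound 3 reports only a limit of the assay, the same limit that compound 1 reached: the limit of > 100000 nM in this assay, at which 2 of the 3 values shown sit. The step between those two cannot be read, so swapping a ring carbon for a ring nitrogen in the group joined through a methyl shows no readable effect, and of the three compounds only compound 2, whose chlorine-bearing ring has no methyl link, gives a true number.

The change from compound 2 to compound 3 alters the chlorine, the methyl link and the point at which the ring is joined all at once, so the compounds shown cannot say which of these matters, and how far compound 1 and compound 3 lie past the limit also stays unknown. A plain pyridin-2-yl with no chlorine, or a pyridin-4-yl joined straight to the nitrogen, would help to pull these changes apart.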